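Amine chain change from compound 1 to compound 3

The source may hold more compounds than are shown below. What is called first, only, known or untested is meant among the compounds shown, and "the series" means these compounds.

- compound 1 `CCCCCN(CCCCC)CCCOc1ccc(S(=O)(=O)c2c(C(C)C)cn3ccccc23)cc1` gives 89.6 nM
- compound 2 `CCCCc1cn2ccccc2c1S(=O)(=O)c1ccc(OCCCN(CCC)CCC)cc1` gives 570 nM

In a functional assay (aorta) with Rattus norvegicus as the target (a lower number here means a stronger inhibitor, a higher number a weaker inhibitor), compound 1 holds the lower of the two numbers at 89.6 nM and is the stronger inhibitor of the pair. Compound 2 sits at 570 nM and that gap lies beyond the usual scatter.

Compound 3 `CCCCN(CCCC)CCCOc1ccc(S(=O)(=O)c2c(C(C)C)cn3ccccc23)cc1` has not yet been measured. It keeps the core of compound 1 and differs in one place (dibutylamino in place of dipentylamino on a saturated chain carbon, three bonds along the chain from an oxygen on an aromatic ring) with dibutylamino in place of dipentylamino on a saturated chain carbon, three bonds along the chain from an oxygen on an aromatic ring.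

Among the measured compounds shown here, no measured pair shows this change alone, and compound 2 differs from compound 1 in more than one place. The starting point for the expectation is therefore compound 1 at 89.6 nM in this assay with no direction favoured. The estimated change is a 1.1-fold higher number from compound 1 to compound 3 (0.05 log units; within the scatter) and no step beyond the scatter is expected. Compound 3 is estimated at 100 nM with an expected range from 35 nM to 300 nM once measured.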

Compound 3, half-maximal inhibitory concentration: 21.6 nM
Compound 3: middle estimate off by 4.6-fold (0.67 log units), on the high side; the measured number lies below the stated range.
By their numbers in this assay, from the lowest: compound 3; then compound 1; then compound 2.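

In this assay, the amine end of the chain proves sensitive to a small change: dibutylamino in place of dipentylamino on a saturated chain carbon, three bonds along the chain from an oxygen on an aromatic ring, gives a 4.1-fold lower number from compound 1 to compound 3 (0.62 log units; beyond the scatter). Among the compounds shown here, this is the first comparison that isolates a single place, so the shift can be assigned to the amine alone, and it shows that the dipentylamino group is not needed: compound 3 gives 21.6 nM without it. Nothing in hand explains why the shorter chains on the amine give the lower number.

A single step between two chain lengths gives a direction only, and compound 2 differs from both compound 1 and compound 3 in more than one place, so it does not extend the comparison. As far as these compounds go, whether the number keeps falling with diethylamino or dimethylamino on the same chain carbon, or whether dibutylamino already marks the lowest point, remains open.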